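Series notes: the acyl group change toward compound 4

A few compounds are considered here, and "the series" means these few. Any claim that something is new, unique, unknown or untested is made for them only; others in the source may bear on it.

Compound 1 `NC(=O)c1c(NC(=O)c2ccccc2Cl)sc2c1CCN(Cc1ccc(Cl)cc1)C2`, compound 2 `COc1ccccc1NC(=S)N1CCc2c(sc(NC(=O)c3ccccc3Cl)c2C(N)=O)C1` and compound 3 `NC(=O)c1c(NC(=O)c2ccccc2Cl)sc2c1CCN(C(=S)Nc1cccnc1)C2` share one core and differ from each other only on the amine nitrogen in a ring or on the amide-type nitrogen. In a functional assay on HeLa cells (Homo sapiens) for antiproliferative activity, with a stated time of 24 h (a higher number here means a weaker inhibitor, a lower number a stronger inhibitor), compound 1 reaches only the limit of the assay, > 50000 nM. Compound 2 likewise gives only a limit, > 50000 nM, in this assay. Compound 3 also stops at a limit, > 50000 nM. The steps a step that the two limits leave unreadable from compound 1 to compound 2, a step that the two limits leave unreadable from compound 1 to compound 3 and a step that the two limits leave unreadable from compound 2 to compound 3 therefore carry no readable size; all that the numbers show is the limit of > 50000 nM in this assay, at which 3 of the 3 values shown sit. Compound 3 thus stands at the limit together with the two others, and no order among the three can be drawn.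

Compound 4 `NC(=O)c1c(NC(=O)c2ccc[nH]2)sc2c1CCN(C(=S)Nc1cccnc1)C2` differs from compound 3 in one place: 1H-pyrrol-2-yl in place of 2-chlorophenyl on a carbonyl carbon. Among the measured compounds shown here, none of the measured steps touches the carbonyl carbon, so no step in this assay bears on this change, and the three limits give neither size nor direction. For the measured compounds named here, the only expectation the numbers support is that compound 4 stays near the limit, which means an expected step that the limit leaves unreadable from compound 3 to compound 4. Compound 4 is accordingly estimated at 60000 nM, with a range from 15000 nM to 250000 nM.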

Compound 4, half-maximal inhibitory concentration: 47400 nM
For compound 4 the middle estimate is 1.3-fold (0.10 log units) above the measured one, and the stated range covers the measured number.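

The carbonyl carbon is touched here for the first time, and in this assay compound 4 gives the first reading among the compounds shown that is a number and not a limit, 47400 nM. Replacing 2-chlorophenyl with 1H-pyrrol-2-yl gives an at least 1.0-fold lower number from compound 3 to compound 4 (0.02 log units; that floor lies within the scatter), so the two compounds cannot be ordered on this result. The reading stands alone, and the remaining compounds shown stay at a limit: the limit of > 50000 nM in this assay, at which 3 of the 4 values shown sit.

The compounds shown do not separate the hydrogen-bond donor counted on 1H-pyrrol-2-yl from the loss of the chlorine or the change from a six-membered to a five-membered ring as the feature that matters at this position. From the compounds shown here alone, whether furan-2-yl or unsubstituted phenyl on the carbonyl carbon would give a number in this assay, and whether 1H-pyrrol-2-yl would still give one with 2-methoxyphenyl in place of pyridin-3-yl on the amide-type nitrogen, remains open.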